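A few compounds are considered here, and "the series" means these few. Any claim that something is new, unique, unknown or untested is made for them only; others in the source may bear on it.

Measured in an ADME assay on Vero cells (Chlorocebus sabaeus) for cytotoxicity, with a stated time of 72 h; a lower number here means a stronger inhibitor, a higher number a weaker inhibitor:

- compound 1 `CCOC(=O)c1cc(/C=C/c2cccc(C(F)(F)F)c2)on1`: > 128000 nM
- compound 2 `CCOC(=O)c1cc(/C=C/c2ccc(OCc3ccccc3)cc2)on1`: > 128000 nM
- compound 3 `CCOC(=O)c1cc(/C=C/c2c(Cl)cncc2Cl)on1`: > 128000 nM

Each of these entries is a limit of the assay and not a number. Among the compounds with values here, compound 1 therefore has no number to its name, and the series so far reads as the limit of > 128000 nM in this assay, at which 3 of the 3 values shown sit. Within the data shown here, no two measured compounds form a single-place step, so the data give no measured size of change.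

The next compound is compound 4 `CCOC(=O)c1cc(/C=C/c2cccc(-c3ccccn3)c2)on1`, which carries pyridin-2-yl in place of trifluoromethyl on an aromatic carbon, meta to a large group: pyridin-2-yl in place of trifluoromethyl on an aromatic carbon.

The expectation rests on compound 1, whose > 128000 nM is a limit. In this assay no step beyond the scatter is expected, and the estimate is a number no higher from compound 1 to compound 4 (the limit leaves the size open). A reading at the limit again is the likeliest outcome, although a number remains possible. For compound 4 the estimated value is 128000 nM, with an expected range from 60000 nM to 256000 nM.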

Compound 4, half-maximal inhibitory concentration: 113000 nM
Beside the measured number, compound 4's estimate is 1.1-fold (0.05 log units) above it; the range from low to high includes it.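

In this assay, within the data shown here, compound 4 gives the first reading that is a number, 113000 nM. Compound 1 gives > 128000 nM, which is a limit of the assay and not a number. Pyridin-2-yl in place of trifluoromethyl on this aromatic carbon gives an at least 1.1-fold lower number from compound 1 to compound 4 (0.05 log units; that floor lies within the scatter), and with a six-membered aromatic ring at this position, the reading stays close to where the rest of the series stands: the limit of > 128000 nM in this assay, at which 3 of the 4 values shown sit.

The compounds shown leave open how an amine or a carboxylic acid at this position would read in this assay, and whether pyridin-3-yl would read as pyridin-2-yl does. As far as these compounds go, with a single step, it also remains open whether the same change on another aromatic carbon would give a similar reading.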